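Swapping the Amide Group for Chloro on the Aryl Ring

The compounds below may be only part of what the source reports. "The series", "measured", "known", "first", "only" and "open" are said of these compounds alone.

Compound 1: `NC(=O)Nc1sc(-c2ccc(C(=O)N3CCOCC3)cc2)cc1C(=O)N[C@H]1CCCNC1` — 610 nM
Compound 2: `NC(=O)Nc1sc(-c2ccccc2)cc1C(=O)NC1CCNCC1` — "not determined" (no result reported)

Compound 1 carries the only number shown: in a functional assay on HT-29 cells (Homo sapiens) (a lower number here means that less compound is needed, a higher number that more compound is needed for the effect), compound 1 gives 610 nM. In this assay compound 2 gives "not determined" (no result reported), so it offers no comparison. Compound 3, `NC(=O)Nc1sc(-c2ccc(Cl)cc2)cc1C(=O)N[C@H]1CCCNC1`, differs from compound 1 in one place: chloro in place of (morpholin-4-yl)carbonyl on an aromatic carbon. Among the measured compounds shown here, no pair of measured compounds separated by a single change is available, so nothing measured points in either direction for this swap. The step of a 1.1-fold lower number from compound 1 to compound 3 (0.04 log units; within the scatter) is expected to fall within the usual scatter. Compound 3 is therefore estimated at 550 nM, with a likely range from 150 nM to 2000 nM.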

Compound 3, half-maximal effective concentration: 40 nM
Beside the measured number, compound 3's estimate is 14-fold (1.14 log units) above it; the whole stated range lies above it.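

In this assay, replacing the large (morpholin-4-yl)carbonyl with a single chloro on the aromatic ring gives a 15-fold lower number from compound 1 to compound 3 (1.18 log units; beyond the scatter), a large step beyond the scatter. This position therefore does not need the morpholine ring or its carbonyl for a low number, and here a single atom does far better than the larger group. Nothing measured here explains why the number falls. The compounds shown leave open whether chloro itself matters or whether another small group, such as fluoro, methyl or an amine, would give a similar number.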